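Chloro Added to the Phenyl of an Inactive Nucleoside

A few compounds are considered here, and "the series" means these few. Any claim that something is new, unique, unknown or untested is made for them only; others in the source may bear on it.

Compound 3 `Nc1ncnn2c([C@@H]3O[C@H](CO)[C@@H](O)[C@H]3O)cc(-c3ccccc3)c12` carries a phenyl group on the shared core. In a functional assay on K562 cells (Homo sapiens) for antiproliferative activity, with a stated time of 72 h (a higher number here means a weaker inhibitor, a lower number a stronger inhibitor), compound 3 gives > 100000 nM, which is a limit of the assay rather than a number. Compound 1 `Nc1ncnn2c([C@@H]3O[C@H](CO)[C@@H](O)[C@H]3O)cc(C#Cc3ccc(F)cc3)c12` also stops at the limit, giving > 100000 nM. Compound 2 `Nc1ncnn2c([C@@H]3O[C@H](CO)[C@@H](O)[C@H]3O)cc(C#Cc3ccccc3)c12` likewise gives > 100000 nM, again a limit. The steps a step that the two limits leave unreadable from compound 1 to compound 2, a step that the two limits leave unreadable from compound 1 to compound 3 and a step that the two limits leave unreadable from compound 2 to compound 3 cannot be read, because of the limit of > 100000 nM in this assay, at which 3 of the 3 values shown sit. Compound 4 `Nc1ncnn2c([C@@H]3O[C@H](CO)[C@@H](O)[C@H]3O)cc(-c3ccc(Cl)cc3)c12` differs from compound 3 by chloro in place of hydrogen on an aromatic carbon. Going by the values given here, no measured step gives a readable size for such a change, so no shift beyond the scatter in this assay is expected, and a further limit seems most likely. Compound 4 is expected to give 150000 nM, within 40000 nM to 500000 nM. This corresponds to an expected step that the limit leaves unreadable from compound 3 to compound 4.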

Compound 4, half-maximal inhibitory concentration: 47800 nM
Compound 4: the middle estimate sits 3.1-fold (0.50 log units) above what was measured, within the range that was stated.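

Going from phenyl to 4-chlorophenyl gives a readable step in this assay, an at least 2.0-fold lower number from compound 3 to compound 4 (0.32 log units; beyond the scatter), so this aromatic carbon responds to a chloro where the earlier compounds showed no readable change. Replacing the alkynyl groups with 4-chlorophenyl also reads, with an at least 2.0-fold lower number from compound 2 to compound 4 (0.32 log units; beyond the scatter) and an at least 2.0-fold lower number from compound 1 to compound 4 (0.32 log units; beyond the scatter). These steps give only a lower bound on size, since one side of each is a limit: the limit of > 100000 nM in this assay, at which 3 of the 4 values shown sit.

From the compounds shown here alone, the full size of the chloro step remains open. So does whether a bromo, a methyl or an amine on the same aromatic carbon would read as the chloro does.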